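A few compounds are considered here, and "the series" means these few. Any claim that something is new, unique, unknown or untested is made for them only; others in the source may bear on it.

Working notes on the series. In an ADME assay on microsomes from liver (Homo sapiens) for metabolic stability, with a stated time of 30 min, tested at 1 uM (a lower number here means that the compound disappears faster, a higher number that the compound lasts longer), compound 1 `COc1ccc2[nH]c(C(=O)N3CC(=O)N(Cc4ccccc4)[C@@H](COc4ccccc4)C3)cc2c1` gives a half-life of 0.65 h and compound 2 `COc1ccc2[nH]c(C(=O)N3CC(=O)N(Cc4ccccc4)[C@@H](COc4ccc(F)cc4)C3)cc2c1` gives 0.317 h on the same read-out. Going by the values given here, compound 2 is the lower of the two numbers so far. Among the compounds with values here, the only measured step is a 2.1-fold lower number from compound 1 to compound 2 (0.31 log units; beyond the scatter) for fluoro in place of hydrogen on an aromatic carbon, modest but beyond the scatter.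

The change to compound 3 `COc1ccc2[nH]c(C(=O)N3CC(=O)N(Cc4ccccc4)[C@@H](CN4CC5CCCCC5C4)C3)cc2c1` is a group of 9 heavy atoms (8 carbon, 1 nitrogen; one five-membered non-aromatic ring with 1 hetero atom, one six-membered non-aromatic ring of carbon only) in place of a group of 8 heavy atoms (6 carbon, 1 oxygen, 1 fluorine; one six-membered aromatic ring of carbon only), on a saturated chain carbon bound to a saturated ring carbon and it removes the 4-fluorophenoxy group whole. Within the data shown here, that measured step touched only a single position on the aromatic ring of this group, so it is a weak guide here, and no measured compound carries the entering group. Among the measured compounds shown here, with only that one downward step from compound 1 to go on, no shift beyond the scatter can be argued from the data in this assay, and a slight drop from compound 2 at 0.317 h is the most that is expected. The expected step is a 1.3-fold lower number from compound 2 to compound 3 (0.10 log units; within the scatter) and the uncertainty around it is wide. Compound 3 is estimated at 0.25 h within a range of 0.08 h to 0.7 h on this read-out.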

Compound 3, half-life: 0.233 h
Compound 3: middle estimate off by 1.1-fold (0.03 log units), on the high side, and the stated range covers the measured number.
By their numbers in this assay, from the lowest: compounds 3 and 2 (each within the scatter of the next); then compound 1.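

In this assay, the change at this saturated chain carbon gives a 1.4-fold lower number from compound 2 to compound 3 (0.13 log units; within the scatter), so an aromatic ring in this group is not needed to stay level with compound 2, even though the whole 4-fluorophenoxy group leaves and a group of two non-aromatic rings enters; the earlier step had altered only a single position on the aromatic ring. Set against the unsubstituted group, the same kind of replacement gives a 2.8-fold lower number from compound 1 to compound 3 (0.45 log units; beyond the scatter), which leaves compound 1 as the only one of the three whose number stands apart beyond the scatter from both others, and shows that phenoxy and the entering group at this carbon can be told apart where 4-fluorophenoxy and the entering group cannot. Nothing available accounts for either step.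

The three compounds leave open whether a morpholine ring, a dimethylamino group or a carboxylic acid at this carbon would give a half-life above that of compound 1 at 0.65 h. They also leave open whether a phenoxy group with chloro or methoxy on its aromatic ring would follow the fluoro step.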